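Swapping trifluoromethyl for fluoro on the shared core

The source may hold more compounds than are shown below. What is called first, only, known or untested is meant among the compounds shown, and "the series" means these compounds.

Measured so far:
Compound 1, `COC(=O)N[C@H](C(=O)N1CCC[C@H]1C(=O)Nc1ccc([C@H]2CC[C@H](c3ccc(NC(=O)[C@@H]4CCCN4C(=O)[C@@H](NC(=O)OC)C(C)C)cc3)N2c2ccc(C(F)(F)F)cc2)cc1)C(C)C`, gives 58%.
Compound 2, `COC(=O)N[C@H](C(=O)N1CCC[C@H]1C(=O)Nc1ccc([C@@H]2CC[C@@H](c3ccc(NC(=O)[C@@H]4CCCN4C(=O)[C@@H](NC(=O)OC)[C@H]4CCOC4)cc3)N2c2ccc(F)cc2)cc1)[C@H]1CCOC1`, gives 41%.
Compound 3, `COC(=O)N[C@H](C(=O)N1CCC[C@H]1C(=O)Nc1ccc([C@H]2CC[C@H](c3ccc(NC(=O)[C@@H]4CCCN4C(=O)[C@@H](NC(=O)OC)[C@H]4CCOC4)cc3)N2c2ccc(F)cc2)cc1)[C@H]1CCOC1`, gives 47%.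

All three numbers come from an ADME assay (liver) for metabolic stability, with Liver microsome (Homo sapiens) as the target, using microsomes, with a stated time of 30 min; on this read-out lower numbers stand for a less stable compound and higher numbers for a more stable compound. Compound 1 stands highest of the three: compound 3 lies closest to it, and compound 2 furthest, both beyond the scatter. Going by the values given here, the only step between compounds that differ in one place is a number 6 percentage points higher from compound 2 to compound 3 (within the scatter), resting on (the fact that compounds 2 and 3 differ only in the configuration as drawn); it concerns configuration alone and says nothing about the substituent on the aromatic ring.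

Compound 4, `COC(=O)N[C@H](C(=O)N1CCC[C@H]1C(=O)Nc1ccc([C@H]2CC[C@H](c3ccc(NC(=O)[C@@H]4CCCN4C(=O)[C@@H](NC(=O)OC)C(C)C)cc3)N2c2ccc(F)cc2)cc1)C(C)C`, is compound 1 with one change: fluoro in place of trifluoromethyl on an aromatic carbon, placed on an aromatic carbon of a six-membered aromatic ring of carbon only, para to a large group. Among the compounds with values here, no measured step bears on this exchange. Compounds 2 and 3 carry fluoro at that place and give lower numbers than compound 1, but they differ from compound 1 in other places as well, so they only hint at direction. A modest fall is therefore expected, a number 9 percentage points lower from compound 1 to compound 4 (within the scatter), near the edge of the scatter. Compound 4 is estimated at 49%, between 35% and 63%.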

Compound 4, percent of the compound remaining: 38%
Beside the measured number, compound 4's estimate is 11 percentage points above it; low and high end bracket the measured number.
By their numbers in this assay, from the lowest: compounds 4, 2 and 3 (each within the scatter of the next); then compound 1.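

In this assay, going by these compounds alone, this is the first direct reading of the exchange at this place, with the rest of the molecule unchanged: the step is a number 20 percentage points lower from compound 1 to compound 4 (beyond the scatter). Going from 4-(trifluoromethyl)phenyl to 4-fluorophenyl therefore changes the percent of compound remaining by more than the usual scatter of repeat measurements, so the choice of group on this aromatic carbon matters for this read-out. Nothing on hand explains why the number falls, as no measurement given here bears on this exchange.

Still open, going by these compounds, is how other groups on the same aromatic carbon would behave, such as chloro, a nitrile, a methoxy group or an amine, since the direct comparison covers only trifluoromethyl and fluoro. Also open, on these data alone, is whether this exchange would give a step of similar size in the setting of compound 3.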